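The source may report more compounds than this note shows. Statements on the series, on what has been measured and on what is new or still open speak of the compounds shown alone.

Of the compounds shown here, three have so far been measured in a functional assay on MGC-803 cells (Homo sapiens) for inhibition, read by MTT assay, with a stated time of 48 h; a higher number here means a weaker inhibitor, a lower number a stronger inhibitor. Compound 1 `CCC(=O)N(Cc1ccc(OC)c(O)c1)c1cc(OC)c(OC)c(OC)c1` gives 50 nM, the lowest of the three numbers. Compound 2 `C/C=C/C(=O)N(Cc1cc(OC)c(OC)c(OC)c1)c1ccc(OC)c(O)c1` gives 6150 nM, and compound 3 `COc1ccc(CNc2cc(OC)c(OC)c(OC)c2)cc1` gives 11400 nM; both lie beyond the scatter from compound 1, which therefore stands as the strongest inhibitor among those measured. Compound 4 `COc1ccc(CN(C(=O)C[Se]C#N)c2cc(OC)c(OC)c(OC)c2)cc1O` has not yet been measured. It differs from compound 1 in one place: a group of 3 heavy atoms (1 carbon, 1 nitrogen, 1 selenium; no ring) in place of one carbon atom, on a saturated chain carbon bound to a carbonyl carbon. For the measured compounds named here, no measured pair shows a change of this kind, so the size of the step is uncertain; a small step, probably toward a weaker inhibitor but possibly none beyond the scatter, is expected in this assay. Compound 4 is accordingly estimated at 80 nM, with a range from 15 nM to 400 nM. This estimate corresponds to an expected step of a 1.6-fold higher number from compound 1 to compound 4 (0.20 log units; within the scatter).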

Compound 4, half-maximal inhibitory concentration: 270 nM
Compound 4: the middle estimate sits 3.4-fold (0.53 log units) below what was measured; low and high end bracket the measured number.
By their numbers in this assay, from the lowest: compound 1; then compound 4; then compounds 2 and 3 (each within the scatter of the next).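

In this assay, replacing the methyl on the saturated chain carbon bound to a carbonyl carbon with the group of 3 heavy atoms (1 carbon, 1 nitrogen, 1 selenium; no ring) gives a 5.4-fold higher number from compound 1 to compound 4 (0.73 log units; beyond the scatter), a modest step toward weaker inhibition. For the compounds shown here, this is the first reading at this position, and it shows that the number responds to a change there while compound 4 still gives 270 nM. Nothing available accounts for the size of this step. As far as these compounds go, it remains open whether the selenium or the nitrile matters more, and what a sulfur atom in place of the selenium, a longer alkyl chain or an amine would do at this carbon.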